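The source may report more compounds than this note shows. Statements on the series, on what has been measured and on what is new or still open speak of the compounds shown alone.

Series notes. In an assay on FRT-Jurkat cells for inhibition of nuclear factor NF-kappa-B complex (Homo sapiens), read by flow cytometry, with a stated time of 24 h, tested at 10 uM (a lower number here means less inhibition, a higher number more inhibition at the concentration tested (going by the name of the read-out)), compound 1 `COc1ccc(Nc2ccc3c(c2)C(=O)N(C2CCC(=O)NC2=O)C3=O)cc1` gives 29%, compound 2 `Cc1ccc(Nc2ccc3c(c2)C(=O)N(C2CCC(=O)NC2=O)C3=O)cc1` gives 5% and compound 3 `CC(=O)c1ccc(Nc2cccc3c2C(=O)N(C2CCC(=O)NC2=O)C3=O)cc1` gives 2%. Compound 2 thus stands second of the three numbers, within the scatter of compound 3 and well under compound 1. Among the measured compounds shown here, the only measured single-point step, a number 24 percentage points lower from compound 1 to compound 2 (beyond the scatter), is the one change at the anilino ring seen so far. Compound 4 `CCCc1ccc(Nc2ccc3c(c2)C(=O)N(C2CCC(=O)NC2=O)C3=O)cc1` carries ethyl in place of hydrogen on a saturated chain carbon bound to an aromatic carbon. For the measured compounds named here, no measured step covers a lengthening of the alkyl group itself, and the methyl-for-methoxy step does not speak to it, so no shift beyond the scatter is expected in this assay. The estimate for compound 4 is 8% (range 0% to 25%), which means an expected step of a number 3 percentage points higher from compound 2 to compound 4 (within the scatter).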

Compound 4, a percentage reported as inhibition, at one concentration (the size of the read-out at that concentration, not a potency): 10%
For compound 4 the middle estimate is 2 percentage points below the measured one, and the stated range covers the measured number.
By their numbers in this assay, from the lowest: compounds 3, 2 and 4 (each within the scatter of the next); then compound 1.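

In this assay, lengthening the methyl of compound 2 to a propyl leaves the number unchanged within the scatter (a number 5 percentage points higher from compound 2 to compound 4 (within the scatter)), so with the added ethyl the number stays level. Propyl also falls short of methoxy (a number 19 percentage points lower from compound 1 to compound 4 (beyond the scatter)), which makes methoxy the one group apart among the three on this aromatic carbon, with methyl and propyl alike. Nothing available gives a cause for this.

On these data alone, whether the methoxy oxygen matters remains open, and an ethoxy or hydroxyl group here could test it. An amine or a longer chain at this place also remains untested in the compounds shown.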